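Ethynyl for benzofuranyl on a shared core

This account rests on a few compounds, and the source may have more. Where it says the series, first, only, none or still open, it means among the compounds named here.

In a functional assay on HCT-116 cells (Homo sapiens), read by MTT assay, with a stated time of 72 h (on this read-out lower numbers stand for stronger inhibition and higher numbers for weaker inhibition), compound 2 `CNc1ncnc2c1c(-c1cc3ccccc3o1)cn2[C@@H]1O[C@H](CO)[C@@H](O)[C@H]1O` gives > 20000 nM, which is a limit of the assay and not a number. Compound 3 `C#Cc1cn([C@@H]2O[C@H](CO)[C@@H](O)[C@H]2O)c2ncnc(NC)c12` differs from it by ethynyl in place of 1-benzofuran-2-yl on an aromatic carbon. Going by the values given here, no measured step isolates this change. Among the compounds with values here, the only guide is compound 1 `C#Cc1cn([C@@H]2O[C@H](CO)[C@@H](O)[C@H]2O)c2ncnc(OC)c12`, which also carries ethynyl and gives 4060 nM in this assay. A shift towards stronger inhibition is therefore expected, with the step estimated as an at least 6.6-fold lower number from compound 2 to compound 3 (0.82 log units; beyond the scatter). For compound 3 the expected value is 3000 nM, with an estimated range of 400 nM to 20000 nM.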

Compound 3, half-maximal inhibitory concentration: > 20000 nM
Compound 3 gave a limit, no number (the forecaster's own chance of this, stated with the estimate: 15%); at least 6.6-fold (0.82 log units) between middle value and limit.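

Replacing ethynyl's partner on the shared core shows that ethynyl alone does not secure a measurable value in this assay: with methylamino in place of methoxy on an aromatic carbon, the result is an at least 4.9-fold higher number from compound 1 to compound 3 (0.69 log units; beyond the scatter). Compound 3 gives > 20000 nM, a limit of the assay and not a number. With ethynyl and 1-benzofuran-2-yl both at a limit, the step between these two groups cannot be read: the limit of > 20000 nM in this assay, at which 2 of the 3 values shown sit.

As far as these compounds go, it remains open what a nitrile or a methyl group on this aromatic carbon would give alongside methylamino. Also open, from the compounds shown here alone, is how 1-benzofuran-2-yl behaves with methoxy in place of methylamino.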